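Cyclic urea in place of open ethylurea on the stilbene core

This account rests on a few compounds, and the source may have more. Where it says the series, first, only, none or still open, it means among the compounds named here.

Measured compounds:
Compound 1, `CCNC(=O)Nc1ccc(/C=C\c2cc(OC)c(OC)c(OC)c2)cc1`: 29000 nM
Compound 2, `CCNC(=O)Nc1ccc(/C=C/c2cccc(Cl)c2)cc1`: > 20000 nM
Compound 3, `Cc1cc(C)cc(/C=C\c2ccc(N3CCNC3=O)cc2)c1`: 15 nM

In a functional assay on HT-1080 cells (Homo sapiens) for inhibition, read by sulforhodamine B assay, with a stated time of 48 h (a lower number here means a stronger inhibitor, a higher number a weaker inhibitor), compound 1 gives 29000 nM, the highest of the two numbers reported. The nearest number is that of compound 3, which is lower, and the gap lies well beyond the scatter. For compound 2 the assay reports only a limit, (the limit of > 20000 nM in this assay, at which 1 of the 3 values shown sits), and no number.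

The unmeasured compound 4, `COc1cc(/C=C\c2ccc(N3CCNC3=O)cc2)cc(OC)c1OC`, differs from compound 1 in one place: 2-oxoimidazolidin-1-yl in place of (ethylcarbamoyl)amino on an aromatic carbon. Compound 3 carries the same 2-oxoimidazolidin-1-yl group on its core and gives 15 nM, so a number of that order is taken as the reference for compound 4. The step expected here, a 1500-fold lower number from compound 1 to compound 4 (3.16 log units; beyond the scatter), would be a large drop in the number, far beyond the scatter. Compound 4 is accordingly estimated at 20 nM, with a range from 3 nM to 200 nM.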

Compound 4, half-maximal inhibitory concentration: 2.3 nM
For compound 4 the middle estimate is 8.7-fold (0.94 log units) above the measured one; measured number outside the range, below it.
By their numbers in this assay, from the lowest: compound 4; then compound 3; then compound 1.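

In this assay, among the compounds shown here, the swap on the aromatic carbon para to a large group gives a 13000-fold lower number from compound 1 to compound 4 (4.10 log units; beyond the scatter), the first reading from two compounds that differ in one place. Both groups have 6 heavy atoms of the same elements, and the visible differences are the five-membered non-aromatic ring and 1 hydrogen-bond donor in place of 2 hydrogen-bond donors; this single pair cannot separate those two differences. Nothing in the data shown gives a cause for the step.

Open, from the compounds shown here alone, is whether a six-membered cyclic urea, a pyrrolidinone ring or an open urea with a methyl group on the nitrogen keeps a number of this order at this position. Also open, going by these compounds, is whether the swap carries over to the core of compound 2, for which only a limit is reported.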